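Fluoro for hydrogen on the pyridine of compound 3

The source may report more compounds than this note shows. Statements on the series, on what has been measured and on what is new or still open speak of the compounds shown alone.

Three compounds sharing one core were tested in a functional assay on A-375 cells (Homo sapiens) for cytotoxicity, read by MTT assay, with a stated time of 72 h, tested at 1 uM; a higher number here means more inhibition of growth at the concentration tested, a lower number less inhibition of growth. Compound 1 `N/C(=N\NC(=S)N1CCCC1)c1ccc(F)cn1` gives 57.9%, compound 2 `Cc1cccc(/C(N)=N/NC(=S)N2CCSCC2)n1` gives 47.2%, and compound 3 `N/C(=N\NC(=S)N1CCSCC1)c1ccccn1` gives 34%, the lowest of the three, with the step of a number 13.2 percentage points lower from compound 2 to compound 3 (beyond the scatter) setting it apart from compound 2. Compound 4 `N/C(=N\NC(=S)N1CCSCC1)c1ccc(F)cn1` differs from compound 3 by one change: fluoro in place of hydrogen on an aromatic carbon. Going by the values given here, no measured step involves this exact change; compound 1, which carries the same fluoro but a different ring on the thiourea, sits higher than compound 3, yet two changes separate them. The account therefore expects a small rise, a number 11 percentage points higher from compound 3 to compound 4 (beyond the scatter), with wide uncertainty. Compound 4 is estimated at 45%, ranging from 28% to 62%.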

Compound 4, percent growth inhibition at one concentration: 55.1%
Compound 4: middle estimate off by 10.1 percentage points, on the low side; low and high end bracket the measured number.
By their numbers in this assay, from the lowest: compound 3; then compounds 2, 4 and 1 (each within the scatter of the next, the first and the last beyond it).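

In this assay, going by these compounds alone, fluoro in place of hydrogen, on the aromatic carbon two atoms from the ring nitrogen and para to a large group, gives a number 21.1 percentage points higher from compound 3 to compound 4 (beyond the scatter) and so provides the first direct reading of this change. With fluoro present, thiomorpholin-4-yl in place of pyrrolidin-1-yl on the thiocarbonyl carbon gives a number 2.8 percentage points lower from compound 1 to compound 4 (within the scatter) and leaves these two rings undistinguished here. No evidence available here explains the step. From the compounds shown here alone, whether chloro or methoxy on this same carbon would match fluoro remains open.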